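The compounds below may be only part of what the source reports. "The series", "measured", "known", "first", "only" and "open" are said of these compounds alone.

In a functional assay on A549 cells (Homo sapiens) for antiproliferative activity, read by MTT assay, with a stated time of 48 h (a higher number here means a weaker inhibitor, a lower number a stronger inhibitor), two compounds with a shared core have been measured so far. Compound 1 `COc1cc(-c2cccc3nc(-c4ccccc4)oc23)cc(OC)c1OC` gives 20300 nM, while compound 2 `COc1cc(-c2cccc3nc(-c4ccc(C)cc4)oc23)cc(OC)c1OC` gives 680 nM, the lower of the two numbers and so the stronger inhibitor. Among the measured compounds shown here, the only measured step, a 30-fold lower number from compound 1 to compound 2 (1.47 log units; beyond the scatter), is large and comes from methyl in place of hydrogen on an aromatic carbon.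

Compound 3 `COc1cc(-c2cccc3nc(-c4ccco4)oc23)cc(OC)c1OC` has not yet been measured. It carries furan-2-yl in place of 4-methylphenyl on an aromatic carbon. This swap removes that methyl, whose addition went with the large step of a 30-fold lower number from compound 1 to compound 2 (1.47 log units; beyond the scatter), so a move back toward a higher number is expected in this assay. For the measured compounds named here, no measured step involves furan-2-yl, which leaves the size uncertain. The expected change is a 5.9-fold higher number from compound 2 to compound 3 (0.77 log units; beyond the scatter). For compound 3 the estimate is 4000 nM, with an expected range of 1000 nM to 20000 nM.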

Compound 3, half-maximal inhibitory concentration: 10300 nM
Compound 3: the middle estimate sits 2.6-fold (0.41 log units) below what was measured; low and high end bracket the measured number.
By their numbers in this assay, from the lowest: compound 2; then compounds 3 and 1 (each within the scatter of the next).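

In this assay, this position, on the five-membered aromatic ring next to the ring nitrogen and next to the ring oxygen, does not keep its low number when 4-methylphenyl gives way to furan-2-yl: the swap brings a 15-fold higher number from compound 2 to compound 3 (1.18 log units; beyond the scatter). Furan-2-yl in place of phenyl brings a 2.0-fold lower number from compound 1 to compound 3 (0.29 log units; within the scatter), so these two groups cannot be told apart here, even though one ring is six-membered and all carbon and the other is five-membered with a hetero atom. Of the three groups, only 4-methylphenyl stands clearly apart from the others.

Nothing available here explains why these groups differ. Going by these compounds, it remains open whether an ethyl group, a chlorine atom, a methoxy group or an amine in place of that methyl would match compound 2 at 680 nM.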